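The source may hold more compounds than are shown below. What is called first, only, known or untested is meant among the compounds shown, and "the series" means these compounds.

Of the compounds shown here, three with a shared spiro-linked core have been measured in an assay on isolated protein for inhibition of RAC-alpha serine/threonine-protein kinase (Homo sapiens); a higher number here means a weaker inhibitor, a lower number a stronger inhibitor. Compound 1 `CCOCCN(C[C@@H](O)CN1CCCC2(CCN(c3ncnc4ccccc34)C2)C1)S(=O)(=O)c1c(C)cccc1C` carries a dimethylphenyl sulfonyl group and gives 38 nM. Compound 2 `Cc1cccc(C)c1S(=O)(=O)N1CCC[C@H]1[C@@H](O)CN1CCC[C@@]2(CCN(c3ncnc(N)c3C3CC3)C2)C1` keeps a dimethylphenyl sulfonyl group but joins the hydroxyl-bearing chain to a five-membered ring, and in this assay compound 2 gives 9 nM. Compound 3 `Nc1ncnc(N2CC[C@@]3(CCCN(C[C@H](O)CNS(=O)(=O)c4ccccc4F)C3)C2)c1C1CC1` has a 2-fluorophenyl sulfonyl group on a simple sulfonamide nitrogen, and in this assay compound 3 gives 81 nM, the highest of the three numbers: compound 1 lies below it, just beyond the usual scatter, while compound 2 sits clearly further below.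

Compound 4 `Cc1ccncc1S(=O)(=O)NC[C@@H](O)CN1CCC[C@@]2(CCN(c3ncnc(N)c3C3CC3)C2)C1` is the next step from compound 3. The change is 4-methylpyridin-3-yl in place of 2-fluorophenyl on a sulfonyl sulfur; everything else in the molecule stays the same. Going by the values given here, no measured pair in this set isolates such a swap on the sulfonyl group, so there is no direct precedent to lean on. An aromatic ring of the same size is exchanged for one carrying a single ring nitrogen and a methyl group, which is the kind of change that often leaves the number roughly where it was. The step from compound 3 to compound 4 is therefore expected to be a 1.0-fold lower number from compound 3 to compound 4 (0.01 log units; within the scatter), not beyond the scatter in either direction. For compound 4 in this assay the estimate is 80 nM, with a range from 30 nM to 220 nM.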

Compound 4, half-maximal inhibitory concentration: 1100 nM
Compound 4: middle estimate off by 14-fold (1.14 log units), on the low side; measured number outside the range, above it.
By their numbers in this assay, from the lowest: compound 2; then compound 1; then compound 3; then compound 4.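

In this assay, the group on the sulfonyl sulfur matters far more than its size and ring type would suggest: 4-methylpyridin-3-yl in place of 2-fluorophenyl gives a 14-fold higher number from compound 3 to compound 4 (1.13 log units; beyond the scatter) even though both groups are six-membered aromatic rings with the same number of heavy atoms. Going by these compounds alone, this is the first comparison in the set that changes only one place, whereas compounds 1 and 2 differ from compound 3 in more than one place and so could not show how sensitive this position is. The swap removes a fluorine and brings in a ring nitrogen, a methyl group and a hydrogen-bond acceptor, but no measurement at hand explains the step or shows which of these differences carries it.

Still open, on these data alone, is whether the ring nitrogen or the methyl group matters more, which an unsubstituted phenyl or a pyridine ring without the methyl group on the same sulfonyl sulfur could help separate. Also open, as far as these compounds go, is whether a non-aromatic group there, such as cyclohexyl or a short alkyl chain, would stay close to compound 3 (81 nM) or fall away as compound 4 does.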